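The compounds below may be only part of what the source reports. "The series", "measured", "known", "first", "only" and "open" are said of these compounds alone.

Measured in a functional assay on MCF7 cells (Homo sapiens) for cytotoxicity, read by MTT assay, with a stated time of 24 h; on this read-out higher numbers stand for weaker inhibition and lower numbers for stronger inhibition:
- compound 1 `CCNc1cc(-c2ccc(NC(=O)Nc3ccc(C)cc3)cc2C(F)(F)F)ccn1`: 9470 nM
- compound 2 `CCNc1cc(-c2ccc(NC(=O)Nc3ccc(OC)cc3)cc2C(F)(F)F)ccn1`: 5740 nM
- compound 3 `CCNc1cc(-c2ccc(NC(=O)Nc3ccc(C(F)(F)F)cc3)cc2C(F)(F)F)ccn1`: 2390 nM

Among these, compound 3 has the lowest number, 2390 nM, which makes it the strongest inhibitor of the set. Its closest neighbour is reached by a 2.4-fold lower number from compound 2 to compound 3 (0.38 log units; beyond the scatter).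

The next compound is compound 4 `CCCNc1cc(-c2ccc(NC(=O)Nc3ccc(C(F)(F)F)cc3)cc2C(F)(F)F)ccn1`, and the change is small: methyl in place of hydrogen on a saturated chain carbon, two bonds along the chain from a nitrogen on an aromatic ring. In words, this is methyl in place of hydrogen on a saturated chain carbon, two bonds along the chain from a nitrogen on an aromatic ring, so ethylamino becomes propylamino.

Among the measured compounds shown here, none of the measured steps touches this chain. All of them swap a group on an aromatic carbon elsewhere in the molecule. a 1.6-fold lower number from compound 1 to compound 2 (0.22 log units; within the scatter) stays within the scatter, while a 4.0-fold lower number from compound 1 to compound 3 (0.60 log units; beyond the scatter) and a 2.4-fold lower number from compound 2 to compound 3 (0.38 log units; beyond the scatter) are modest. These steps show only how far one small change has moved the number in this series, and they say nothing about a longer chain. With no direction supported by the data, no step beyond the scatter is expected in this assay, although a modest move either way remains possible.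

The expected result is a 1.0-fold higher number from compound 3 to compound 4 (0.00 log units; within the scatter).

For compound 4 the estimate is 2400 nM, with an expected range from 1100 nM to 5000 nM.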

Compound 4, half-maximal inhibitory concentration: 7680 nM
Estimate against measurement, compound 4: 3.2-fold (0.51 log units) below, outside the stated range (above it).
By their numbers in this assay, from the lowest: compound 3; then compounds 2, 4 and 1 (each within the scatter of the next).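

Lengthening ethylamino to propylamino gives a 3.2-fold higher number from compound 3 to compound 4 (0.51 log units; beyond the scatter) in this assay, so the chain on the amine nitrogen is a place where even a single added methyl can shift the result. The earlier compounds shown here varied only a group on an aromatic carbon, and the steps that went beyond the scatter there, a 4.0-fold lower number from compound 1 to compound 3 (0.60 log units; beyond the scatter) and a 2.4-fold lower number from compound 2 to compound 3 (0.38 log units; beyond the scatter), both ended in the lower number, meaning stronger inhibition; this first change to the chain is also modest in size, but it goes the other way, towards weaker inhibition. Nothing shown here gives a reason for this shift.

A single step cannot show whether the number depends on chain length in a steady way, so a butyl chain, a branched isopropyl group or a smaller methyl group on that nitrogen could each behave differently. On these data alone, it also remains open whether the same lengthening would give a similar step with the methyl of compound 1 or the methoxy of compound 2 in place of the trifluoromethyl.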